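Swapping the Ester Group of a Nitroanilide Series

The source may report more compounds than this note shows. Statements on the series, on what has been measured and on what is new or still open speak of the compounds shown alone.

Of the compounds shown here, three sharing one core have been measured in a functional assay on NFS-60 cells (Mus musculus) for inhibition, read by MTT assay, with a stated time of 72 h; on this read-out lower numbers stand for stronger inhibition and higher numbers for weaker inhibition. Compound 1 `O=C(OC1(C(=O)Nc2ccc([N+](=O)[O-])cc2)CCCCC1)c1ccc(Cl)cc1` gives 10.3 nM. Compound 2 `CCOC(=O)c1ccccc1C(=O)OC1(C(=O)Nc2ccc([N+](=O)[O-])cc2)CCCCC1` gives 488 nM. Compound 3 `CCC(=O)OC1(C(=O)Nc2ccc([N+](=O)[O-])cc2)CCCCC1` gives 6.4 nM, the lowest of the three numbers, although the step of a 1.6-fold lower number from compound 1 to compound 3 (0.21 log units; within the scatter) is within the scatter, while compound 2 sits far above it, beyond the scatter.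

Compound 4 `CC(=O)Oc1ccccc1C(=O)OC1(C(=O)Nc2ccc([N+](=O)[O-])cc2)CCCCC1` has not yet been measured. It differs from compound 3 in one place: 2-acetoxyphenyl in place of ethyl on a carbonyl carbon. Among the compounds with values here, only one measured step, from compound 3 to compound 1 in reverse, bears directly on this position, and it was small. Yet compound 2, which also carries a substituted aromatic ring on that carbonyl carbon, shows a much higher number than either, so compound 4 is expected to land well above compound 3, with a step of a 23-fold higher number from compound 3 to compound 4 (1.37 log units; beyond the scatter) in this assay. The estimate for compound 4 is therefore 150 nM, within a range from 25 nM to 900 nM.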

Compound 4, half-maximal inhibitory concentration: 11.3 nM
Compound 4: the middle estimate sits 13-fold (1.12 log units) above what was measured; the whole stated range lies above it.
By their numbers in this assay, from the lowest: compounds 3, 1 and 4 (each within the scatter of the next); then compound 2.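

In this assay a substituted aromatic ring on this carbonyl carbon does not by itself bring a high number: 2-acetoxyphenyl in place of ethyl (a 1.8-fold higher number from compound 3 to compound 4 (0.25 log units; within the scatter)) and in place of 4-chlorophenyl (a 1.1-fold higher number from compound 1 to compound 4 (0.04 log units; within the scatter)) both leave the reading within the scatter. The large step lies instead with the group carried on that ring, acetoxy in place of ethoxycarbonyl on an aromatic carbon (a 43-fold lower number from compound 2 to compound 4 (1.64 log units; beyond the scatter)). Among these four compounds, then, compound 2 alone stands apart.

As far as these compounds go, whether that sharp step belongs to ethoxycarbonyl alone stays open, and a carboxylic acid or an amine on the same ring, or a longer chain in place of ethyl, would show how far this pattern reaches. Nothing available explains why acetoxy and ethoxycarbonyl differ so sharply.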